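Aryl in place of cyclopropyl: expected cytotoxicity of compound 4

A few compounds are considered here, and "the series" means these few. Any claim that something is new, unique, unknown or untested is made for them only; others in the source may bear on it.

Compound 2 `O=C(Nc1ccc(NCC2CC2)cc1Cl)c1cc(Cl)ccc1O` is the reference for this step. In an ADME assay on A549 cells (Homo sapiens) for cytotoxicity, read by resazurin assay, with a stated time of 48 h (on this read-out higher numbers stand for lower toxicity in this test and lower numbers for higher toxicity in this test), compound 2 gives 14400 nM, the lowest of the three numbers recorded so far. Compound 1 `CCCNc1ccc(NC(=O)c2cc(Cl)ccc2O)c(Cl)c1` gives 22500 nM in this assay, and compound 3 `O=C(Nc1ccc(NCc2ccc(Cl)cc2)cc1Cl)c1cc(Cl)ccc1O` gives 59700 nM. Among the measured steps, a 1.6-fold lower number from compound 1 to compound 2 (0.19 log units; within the scatter), while a 2.7-fold higher number from compound 1 to compound 3 (0.42 log units; beyond the scatter) and a 4.1-fold higher number from compound 2 to compound 3 (0.62 log units; beyond the scatter).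

Compound 4 `O=C(Nc1ccc(NCc2ccc(O)cc2)cc1Cl)c1cc(Cl)ccc1O` is not yet measured. Relative to compound 2 the change is 4-hydroxyphenyl in place of cyclopropyl on a saturated chain carbon bound to a nitrogen on an aromatic ring. The step that bears most directly on it is a 4.1-fold higher number from compound 2 to compound 3 (0.62 log units; beyond the scatter), where a substituted phenyl also replaced cyclopropyl at the same place; a 2.7-fold higher number from compound 1 to compound 3 (0.42 log units; beyond the scatter) points the same way. Nothing measured separates 4-hydroxyphenyl from 4-chlorophenyl, so the direction is taken from compound 3 and the size is held somewhat short of it. In this assay compound 4 is therefore expected to give 40000 nM, with a range from 15000 nM to 100000 nM. That estimate corresponds to a 2.8-fold higher number from compound 2 to compound 4 (0.44 log units; beyond the scatter), a higher number beyond the scatter.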

Compound 4, half-maximal cytotoxic concentration: 116000 nM
Compound 4: the middle estimate sits 2.9-fold (0.46 log units) below what was measured; the measured number lies above the stated range.
By their numbers in this assay, from the lowest: compounds 2 and 1 (each within the scatter of the next); then compounds 3 and 4 (each within the scatter of the next).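

In this assay, among these compounds, 4-hydroxyphenyl in place of cyclopropyl gives an 8.1-fold higher number from compound 2 to compound 4 (0.91 log units; beyond the scatter) and 4-hydroxyphenyl in place of ethyl gives a 5.2-fold higher number from compound 1 to compound 4 (0.71 log units; beyond the scatter) so compound 3 is no longer the only compound with a substituted phenyl on the saturated chain carbon bound to a nitrogen on an aromatic ring to show a number beyond the scatter of compound 2. Hydroxy in place of chloro on an aromatic carbon gives a 1.9-fold higher number from compound 3 to compound 4 (0.29 log units; within the scatter) so this assay does not separate compound 3 from compound 4, and the choice between these two substituents is not resolved here. Nothing at hand gives a reason for these steps.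

Open, from the compounds shown here alone, is whether an unsubstituted phenyl at this place belongs with compound 3 and compound 4. Also open, going by these compounds, is how a ring carrying an amine or a carboxylic acid would read in this test.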